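Phenyl for tert-butyl on a nitrofuryl chalcone scaffold

The compounds below may be only part of what the source reports. "The series", "measured", "known", "first", "only" and "open" are said of these compounds alone.

Among the compounds with values here, compound 1, with the structure `CC(C)(C)c1ccc(C(=O)/C=C/c2ccc([N+](=O)[O-])o2)cc1`, is the only member of this small set that carries a result. In an ADME assay on Vero cells (Chlorocebus sabaeus) for cytotoxicity, read by resazurin assay, with a stated time of 72 h (on this read-out lower numbers stand for higher toxicity in this test and higher numbers for lower toxicity in this test), compound 1 gives > 100000 nM, and this is a limit of the measurement rather than a number. The evidence on that point is plain: the limit of > 100000 nM in this assay, at which 1 of the 3 values shown sits. Compound 2, with the structure `CC(C)(C)c1ccc(C(=O)/C=C/c2ccco2)cc1`, returns only "not determined" (no result reported) in this assay. Compound 3, with the structure `O=C(/C=C/c1cccc([N+](=O)[O-])c1)c1ccc(N2CCCCC2)cc1`, likewise returns "not determined" (no result reported) in this assay. Within the data shown here, with no pair of measured compounds differing in a single place, there is no measured step to lean on, and compound 1 therefore stands alone, at the limit, among the values shown.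

Compound 4, with the structure `O=C(/C=C/c1ccc([N+](=O)[O-])o1)c1ccc(-c2ccccc2)cc1`, is the compound still to be tested. It differs from compound 1 by phenyl in place of tert-butyl on an aromatic carbon. Since compound 1 sits at the limit, the step from compound 1 to compound 4 is expected to be none beyond the scatter, as a number no higher from compound 1 to compound 4 (the limit leaves the size open) expresses. For compound 4 in this assay the expected value is 100000 nM, with a range from 40000 nM to 300000 nM, and a fresh limit rather than a number is the more likely outcome.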

Compound 4, half-maximal cytotoxic concentration: > 100000 nM
Compound 4: no number, only a limit (the forecaster's own chance of this, stated with the estimate: 70%); the middle value lies on the limit itself.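

In this assay compound 1 and compound 4 both end at a limit rather than a number, so no step can be read for phenyl in place of tert-butyl on an aromatic carbon: the limit of > 100000 nM in this assay, at which 2 of the 4 values shown sit.

The compounds shown leave open where the true values of compound 1 and compound 4 lie, and whether this exchange changes them at all.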